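A Chloro for Hydroxy Swap Awaiting Cytotoxicity Data

The source may report more compounds than this note shows. Statements on the series, on what has been measured and on what is new or still open speak of the compounds shown alone.

Three compounds sharing one core have been examined in an ADME assay on cells (Mus musculus, strain BALB/C) for cytotoxicity, read by MTT assay, with a stated time of 24 h; a lower number here means that less compound is tolerated, a higher number that more compound is tolerated. Compound 1 `Cc1ccc(C(=O)N/N=C/c2ccccc2O)c(O)c1` gives 761000 nM in this assay. Compound 2 `Cc1ccc(C(=O)N/N=C/c2ccc([N+](=O)[O-])cc2)c(O)c1` gives 734000 nM, and compound 3 `Cc1ccc(C(=O)N/N=C/c2ccc(F)cc2)c(O)c1` gives 568000 nM. Compound 1 holds the highest of the three numbers, yet its gaps to compound 2 and to compound 3 both lie within the scatter, so no ranking among the three can be claimed. Going by the values given here, the single one-point step measured so far, a 1.3-fold lower number from compound 2 to compound 3 (0.11 log units; within the scatter), is likewise within the scatter.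

Compound 4 `Cc1ccc(C(=O)N/N=C/c2ccccc2Cl)c(O)c1` differs from compound 1 by chloro in place of hydroxy on an aromatic carbon. Among the compounds with values here, no measured pair shows this particular change, and the one step that is available concerns a different group and a different part of the molecule. Within the data shown here, the only guidance is that every change seen so far has stayed within the scatter, so the step from compound 1 to compound 4 is expected to do the same: a 1.1-fold lower number from compound 1 to compound 4 (0.04 log units; within the scatter). Compound 4 is therefore estimated at 700000 nM, with a range from 350000 nM to 1400000 nM.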

Compound 4, half-maximal cytotoxic concentration: 125000 nM
The estimate for compound 4 lay 5.6-fold (0.75 log units) above the measured number; measured number below the stated range.
By their numbers in this assay, from the lowest: compound 4; then compounds 3, 2 and 1 (each within the scatter of the next).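

In this assay, chloro in place of hydroxy gives a 6.1-fold lower number from compound 1 to compound 4 (0.78 log units; beyond the scatter) and so is the first one-point step shown here to lie beyond the scatter. Going by these compounds alone, this place, on an aromatic carbon ortho to a large group, is therefore not indifferent to which group it carries, unlike anything the earlier compounds could show. The hydroxy that leaves counts 1 hydrogen-bond donor and 1 hydrogen-bond acceptor and the chloro that enters counts 0 of each, but no measurement shown ties the lower number to that difference or to any other property of the two groups.

Going by these compounds, whether fluoro or bromo at this place would follow chloro remains open. So does whether methoxy or an amine there would stay with hydroxy in compound 1 or also give a lower number.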